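The source may report more compounds than this note shows. Statements on the series, on what has been measured and on what is new or still open speak of the compounds shown alone.

Measured in an ADME assay on BHK cells (Mesocricetus auratus) for cytotoxicity, read by MTT assay, with a stated time of 96 h; on this read-out lower numbers stand for higher toxicity in this test and higher numbers for lower toxicity in this test: compound 1 `FC(F)(F)c1cccc(NC(=S)Nc2ccc(Cl)cc2)c1` gives 10000 nM; compound 2 `CC[C@H]1CC[C@H](c2ccc(NC(=S)Nc3cccc(C(F)(F)F)c3)cc2)CC1` gives 10000 nM; compound 3 `CCOC(=O)c1ccc(NC(=S)Nc2cccc(C(F)(F)F)c2)cc1` gives 50000 nM.

Compound 1 stands level with compound 2 at the digits shown, and these two are together the lowest of the three numbers in this assay; the step of no change at the digits printed from compound 1 to compound 2 (within the scatter) lies within the scatter. Its furthest neighbour is compound 3, reached by the step of a 5.0-fold higher number from compound 1 to compound 3 (0.70 log units; beyond the scatter), a modest rise. The same size of rise is seen in the step of a 5.0-fold higher number from compound 2 to compound 3 (0.70 log units; beyond the scatter).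

Compound 4 `CC(=O)NC(=S)Nc1cccc(C(F)(F)F)c1` differs from compound 1 in one place: acetyl in place of 4-chlorophenyl on an amide-type nitrogen. Within the data shown here, none of the measured steps touches this place; each of them swapped a group on an aromatic carbon while keeping the 4-chlorophenyl itself, so they give no direct guide to what losing that ring and gaining an acetyl will do in this assay. Among the measured compounds shown here, with only this weak guidance, the expected step is a 2.0-fold higher number from compound 1 to compound 4 (0.30 log units; within the scatter), a small rise that may well stay within the scatter. Compound 4 is therefore estimated at 20000 nM, with a range from 5000 nM to 100000 nM.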

Compound 4, half-maximal cytotoxic concentration: > 100000 nM
Compound 4 gave a limit, no number; the forecaster's own chance of this, stated with the estimate: 25%; middle value at least 5.0-fold (0.69 log units) away from the limit.
By their numbers in this assay, from the lowest: compounds 1 and 2 (each within the scatter of the next); then compound 3. At a limit, above all of these: compound 4.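

In this assay, compound 4 gives > 100000 nM, which is a limit of the assay and not a number. Acetyl in place of 4-chlorophenyl on an amide-type nitrogen gives an at least 10-fold higher number from compound 1 to compound 4 (1.00 log units; beyond the scatter). This is the first change shown at this place, and it moves the number further than either earlier step that raised it, both of which swapped a group on an aromatic carbon, though the full size of this step cannot be read from a limit.

This single swap removes the ring and adds the acetyl together, so it leaves open which of the two goes with the rise. A benzoyl group or a propyl chain on that same nitrogen would help to separate the two, since the first has both a carbonyl and a ring and the second has neither.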